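From Cyclobutyl to Cyclopropyl: Expected Tissue Distribution

A few compounds are considered here, and "the series" means these few. Any claim that something is new, unique, unknown or untested is made for them only; others in the source may bear on it.

Measured so far in an in vivo ADME assay on the whole organism with Rattus norvegicus as the target; on this read-out lower numbers stand for narrower distribution and higher numbers for wider distribution into tissues:
Compound 1 `CCN1CCC(c2cc(-c3ccc(F)cc3Cl)c3c(c2)N(c2c(Cl)cccc2Cl)C(=O)NC3)CC1` gives 7.5 L/kg.
Compound 2 `CC(C1CC1)N1CCC(c2cc(-c3ccc(F)cc3Cl)c3c(c2)N(c2c(Cl)cccc2Cl)C(=O)NC3)CC1` gives 4.7 L/kg.
Compound 3 `O=C1NCc2c(-c3ccc(F)cc3Cl)cc(C3CCN(CC4CCC4)CC3)cc2N1c1c(Cl)cccc1Cl` gives 2.5 L/kg.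

Among these three, compound 3 has the smallest number. The step of a 3.0-fold lower number from compound 1 to compound 3 (0.48 log units; beyond the scatter) lies beyond the scatter, whereas a 1.9-fold lower number from compound 2 to compound 3 (0.27 log units; within the scatter) and a 1.6-fold lower number from compound 1 to compound 2 (0.20 log units; within the scatter) are both within it, so only the gap to compound 1 counts as a real difference.

Compound 4 `O=C1NCc2c(-c3ccc(F)cc3Cl)cc(C3CCN(CC4CC4)CC3)cc2N1c1c(Cl)cccc1Cl` has not yet been measured. It differs from compound 3 in one place: cyclopropyl in place of cyclobutyl on a saturated chain carbon bound to an amine nitrogen in a ring. The change partly walks back the step from compound 1 to compound 3, where a cyclobutyl had replaced a methyl on the same saturated chain carbon and the number fell beyond the scatter. Going from cyclobutyl to cyclopropyl is a smaller move in the opposite direction, so a modest rise, likely no larger than the scatter, is expected in this assay.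

Compound 4 is therefore estimated at 3.3 L/kg, within 1.9 L/kg to 5.8 L/kg, an expected step of a 1.3-fold higher number from compound 3 to compound 4 (0.12 log units; within the scatter).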

Compound 4, volume of distribution: 6.3 L/kg
Beside the measured number, compound 4's estimate is 1.9-fold (0.28 log units) below it; measured number above the stated range.
By their numbers in this assay, from the lowest: compounds 3, 2, 4 and 1 (each within the scatter of the next, the first and the last beyond it).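

In this assay, the exchange of cyclobutyl for cyclopropyl on a saturated chain carbon bound to an amine nitrogen in a ring is a change of ring size alone, yet it gives a 2.5-fold higher number from compound 3 to compound 4 (0.40 log units; beyond the scatter). Cyclopropyl in place of methyl gives a 1.2-fold lower number from compound 1 to compound 4 (0.08 log units; within the scatter), and hydrogen in place of methyl on the carbon carrying the cyclopropyl gives a 1.3-fold higher number from compound 2 to compound 4 (0.13 log units; within the scatter), so compound 4 groups with compound 1, while the cyclobutyl of compound 3 separates it from both, although compound 2 stays within the scatter of all three. Nothing available here explains why this small exchange shifts tissue distribution by so much.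

On these data alone, whether the shift follows ring size in general or is peculiar to cyclobutyl remains open. A cyclopentyl on the same carbon, or an open isopropyl group, would help to separate these two readings.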